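The source may report more compounds than this note shows. Statements on the series, on what has been measured and on what is new or still open speak of the compounds shown alone.

Values so far in a functional assay on BXPC-3 cells (Homo sapiens) for antiproliferative activity, read by MTT assay, with a stated time of 24 h (a higher number here means a weaker inhibitor, a lower number a stronger inhibitor), are:
- compound 1 `CCn1c(C(=O)NCC(=O)OC)ccc1C(CC)(CC)c1ccc(OCS(=O)(=O)c2ccccc2)c(C)c1` gives 20000 nM
- compound 2 `CCn1c(C(=O)NC(C)(C)CO)ccc1C(CC)(CC)c1ccc(OCS(=O)(=O)c2ccccc2)c(C)c1` gives 18300 nM
- compound 3 `CCn1c(C(=O)N[C@@H](C(=O)O)C(C)C)ccc1C(CC)(CC)c1ccc(OCS(=O)(=O)c2ccccc2)c(C)c1` gives 13900 nM

Compound 3 at 13900 nM cannot be separated from the other two, as its value lies within the scatter of both. The next structure is compound 4 `CCn1c(C(=O)N[C@@H](CC(=O)O)C(=O)O)ccc1C(CC)(CC)c1ccc(OCS(=O)(=O)c2ccccc2)c(C)c1`, with 1,2-dicarboxyethyl in place of 1-carboxy-2-methylpropyl on an amide-type nitrogen as the difference: 1,2-dicarboxyethyl in place of 1-carboxy-2-methylpropyl on an amide-type nitrogen.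

Three measured steps changed the group on this same nitrogen, namely a 1.1-fold lower number from compound 1 to compound 2 (0.04 log units; within the scatter) and a 1.4-fold lower number from compound 1 to compound 3 (0.16 log units; within the scatter) and a 1.3-fold lower number from compound 2 to compound 3 (0.12 log units; within the scatter) and all stayed within the scatter. Within the data shown here, no measured compound carries 1,2-dicarboxyethyl, so this evidence is indirect. No step beyond the scatter is expected in this assay, and no direction is favoured. The estimated move is a 1.1-fold higher number from compound 3 to compound 4 (0.03 log units; within the scatter) and stays within the scatter. Compound 4 is expected at 15000 nM with an estimated range of 8000 nM to 30000 nM for now.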

Compound 4, half-maximal inhibitory concentration: > 50000 nM
Compound 4: a limit, no number (the forecaster's own chance of this, stated with the estimate: 20%); middle value at least 3.3-fold (0.52 log units) from the limit.
By their numbers in this assay, from the lowest: compounds 3, 2 and 1 (each within the scatter of the next). At a limit, above all of these: compound 4.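

In this assay compound 4 gives > 50000 nM, which is a limit and not a number. Among these compounds, earlier changes on this amide-type nitrogen all stayed within the scatter, so the position looked insensitive, but 1,2-dicarboxyethyl is the first group there to separate from the others. It gives an at least 3.5-fold higher number from compound 3 to compound 4 (0.55 log units; beyond the scatter), an at least 2.7-fold higher number from compound 2 to compound 4 (0.43 log units; beyond the scatter) and an at least 2.5-fold higher number from compound 1 to compound 4 (0.39 log units; beyond the scatter).

From the compounds shown here alone, it remains open whether this shift follows the second carboxylic acid of 1,2-dicarboxyethyl specifically, or would also appear with its methyl ester or an amine on that chain. Going by these compounds, the true size of the step also remains open.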